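A few compounds are considered here, and "the series" means these few. Any claim that something is new, unique, unknown or untested is made for them only; others in the source may bear on it.

Measured so far:
In a functional assay, read by spectrophotometry, with a stated time of 30 min (a higher number here means that more compound is needed for the effect, a lower number that less compound is needed), compound 1 `O=C(/C=C/c1ccc(O)c(O)c1)N1CCCN(S(=O)(=O)c2cccc3cnccc23)CC1` gives 10000 nM.
In this assay compound 2 `O=C(CCc1ccc(O)c(O)c1)N1CCN(S(=O)(=O)c2cccc3cnccc23)CC1` gives 10100 nM.
In this assay compound 3 `COc1cc(/C=C/C(=O)N2CCCN(S(=O)(=O)c3cccc4cnccc34)CC2)ccc1O` gives 9610 nM.

The three measured compounds sit close together in this assay, and the differences among their numbers are within the scatter of the measurement, so no ordering among them can be read from these values.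

Compound 4 `COc1cc(CCC(=O)N2CCN(S(=O)(=O)c3cccc4cnccc34)CC2)ccc1O` has not yet been measured. It differs from compound 2 by a single change, (methyl in place of hydrogen on an oxygen on an aromatic ring). The same change is already seen once among the measured compounds, from compound 1 to compound 3, where it reads (methyl in place of hydrogen on an oxygen on an aromatic ring). That step gave a 1.0-fold lower number from compound 1 to compound 3 (0.02 log units; within the scatter), that is, no real movement in the number. The surroundings of the changed oxygen are described in the same words in both cases, so this is the same change made on a different core. How the core of compound 2 differs from the core of compound 1 is not broken down here.

Among the compounds with values here, since the earlier step was within the scatter, the expectation for compound 4 is that the step from compound 2 to compound 4 will also be small, a 1.0-fold lower number from compound 2 to compound 4 (0.00 log units; within the scatter), because the single comparable step is a 1.0-fold lower number from compound 1 to compound 3 (0.02 log units; within the scatter). Compound 4 is therefore estimated at 10000 nM in this assay, with a likely range from 5000 nM to 20000 nM.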

Compound 4, half-maximal effective concentration: 10300 nM
The estimate for compound 4 lay 1.0-fold (0.01 log units) below the measured number; the measured number falls inside the stated range.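

The step on this second core is a 1.0-fold higher number from compound 2 to compound 4 (0.01 log units; within the scatter), so going from 3,4-dihydroxyphenyl to 4-hydroxy-3-methoxyphenyl again brings no real movement in this assay. Set side by side, the two steps do not differ, so on these two cores the change carries over as a step too small to read: the same change on two cores in this assay, a 1.0-fold lower number (0.02 log units; within the scatter) from compound 1 to compound 3 and a 1.0-fold higher number (0.01 log units; within the scatter) from compound 2 to compound 4, 1.1-fold (0.03 log units) apart, within the scatter of two such steps. Within the data shown here, this is agreement between only two pairs of compounds, and since neither step rises above the scatter, it shows that the change stayed silent twice, not that a real effect was carried from one core to the other, why the hydroxy and methoxy forms read alike, or that a further core would behave the same way.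

The compounds shown leave open whether a longer chain on this oxygen, such as ethyl or propyl, or an amine or a carboxylic acid in place of the hydroxy, would read any differently in this assay. They also leave open what happens when the remaining hydroxy of the 4-hydroxy-3-methoxyphenyl group is capped with a methyl as well, so that the ring carries no hydroxy at all.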